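The source may hold more compounds than are shown below. What is called first, only, known or untested is meant among the compounds shown, and "the series" means these compounds.

Among the three measured compounds, compound 2 `Cc1cccc2[nH]c(-c3n[nH]c4ncc(-c5cncc6ccccc56)cc34)nc12` gives the highest number in a functional assay on HCT-116 cells (Homo sapiens) for antiproliferative activity (a lower number here means a stronger inhibitor, a higher number a weaker inhibitor), at 1640 nM. Its nearest neighbour is compound 1 `c1ccc2c(-c3cnc4[nH]nc(-c5nc6ccccc6[nH]5)c4c3)cncc2c1`, which gives 550 nM in this assay, and the step of a 3.0-fold higher number from compound 1 to compound 2 (0.47 log units; beyond the scatter) shows that adding a methyl group cost potency. Compound 3 `COCc1cccc2[nH]c(-c3n[nH]c4ncc(-c5ccncc5)cc34)nc12` differs from compound 2 in several places. In this assay compound 3 gives 62 nM, the lowest number of the three.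

Compound 4 `CC(C)OCc1cccc2[nH]c(-c3n[nH]c4ncc(-c5cncc6ccccc56)cc34)nc12` is built from compound 2 by a single change: isopropoxy in place of hydrogen on a saturated chain carbon bound to an aromatic carbon. Within the data shown here, the only directly comparable step is the one from compound 1 to compound 2, which involved the methyl group itself rather than a substituent on it, so it gives limited guidance. Compound 3 shows that a larger chain on the same part of the core can go together with a much lower number, though the other difference between compound 3 and compound 2 prevents that being read as a clean effect of the chain alone.

On this basis, a modest improvement is expected for compound 4, roughly a 3.3-fold lower number from compound 2 to compound 4 (0.52 log units; beyond the scatter). The estimate for compound 4 in this assay is therefore 500 nM, with a plausible range from 150 nM to 1600 nM.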

Compound 4, half-maximal inhibitory concentration: 2880 nM
For compound 4 the middle estimate is 5.8-fold (0.76 log units) below the measured one, outside the stated range (above it).
By their numbers in this assay, from the lowest: compound 3; then compound 1; then compounds 2 and 4 (each within the scatter of the next).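

In this assay, extending the methyl group of compound 2 to isopropoxymethyl gives no difference that can be separated from ordinary assay variation: a 1.8-fold higher number from compound 2 to compound 4 (0.24 log units; within the scatter). Measured against the unsubstituted compound, the two substituted compounds point the same way, with a 3.0-fold higher number from compound 1 to compound 2 (0.47 log units; beyond the scatter) and a 5.2-fold higher number from compound 1 to compound 4 (0.72 log units; beyond the scatter), so among these three compounds, hydrogen on this aromatic carbon gives a lower number than either the methyl or the isopropoxymethyl group, and the two groups cannot be told apart from each other. No measurement available here offers an explanation for this result.

As far as these compounds go, whether a different kind of group on the same saturated chain carbon, such as an amine or a carboxylic acid, or a longer chain, would behave like isopropoxy remains open. Compound 2 differs in several places from compound 3, which gives 62 nM, so how much of that low number comes from the chain and how much from the other differences cannot be read from the compounds shown.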